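This account rests on a few compounds, and the source may have more. Where it says the series, first, only, none or still open, it means among the compounds named here.

Three compounds share a core in which a saturated ring nitrogen attaches to an aromatic two-ring system, with an amide hanging off the saturated ring. Compound 1 `Cc1cccc(Oc2ccnc(N3CCC[C@H]3C(=O)NCc3cccnc3)n2)c1` carries a pyridin-3-yl methyl group on the amide nitrogen. In an assay on isolated protein for inhibition of ribosomal protein S6 kinase beta-1 (Homo sapiens), read by HTRF, tested at 10 uM (a higher number here means more inhibition at the concentration tested (going by the name of the read-out), a lower number less inhibition), compound 1 gives 16%, the highest of the three numbers, though its lead is within the usual scatter. Compound 2 `CN(CCCn1ccnc1)C(=O)[C@@H]1CCCN1c1nccc(Nc2ccccc2)n1` gives 6% and compound 3 `O=C(C1CCN(c2nccc(Nc3ccccc3)n2)CC1)N1CC[C@@H](O)C1` gives 10%; all three sit close together, so none can be called stronger than another.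

Compound 4 `Cc1cccc(Oc2ccnc(N3CCC[C@H]3C(=O)NCCCn3ccnc3)n2)c1` has not yet been measured. It differs from compound 1 in one place: 2-(1H-imidazol-1-yl)ethyl in place of pyridin-3-yl on a saturated chain carbon bound to an amide-type nitrogen. The pyridin-3-yl leaves and 2-(1H-imidazol-1-yl)ethyl enters, on a saturated chain carbon bound to an amide-type nitrogen. Compound 2 already carries a 3-(1H-imidazol-1-yl)propyl on its amide, and it gives 6%, so no gain is expected. The step of a number 4 percentage points lower from compound 1 to compound 4 (within the scatter) is expected to stay within the scatter. For compound 4 the estimate is 12%, between 0% and 28%.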

Compound 4, a percentage reported as inhibition, at one concentration (the size of the read-out at that concentration, not a potency): 7%
For compound 4 the middle estimate is 5 percentage points above the measured one, within the range that was stated.
By their numbers in this assay, from the lowest: compounds 2, 4, 3 and 1 (each within the scatter of the next).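

In this assay, putting 2-(1H-imidazol-1-yl)ethyl in place of pyridin-3-yl on a saturated chain carbon bound to an amide-type nitrogen gives a number 9 percentage points lower from compound 1 to compound 4 (within the scatter). This is the first pair of compounds shown that differ in one place, and it offers a direct comparison that the earlier compounds could not. At this position the two groups cannot be told apart in this measurement, and nothing available offers an explanation of the result.

As far as these compounds go, it remains open whether any other group at this position would give a number clearly separate from these, such as a plain phenyl ring in place of pyridin-3-yl or a carboxylic acid or primary amine at the end of the chain. One matched pair also cannot show whether the same swap would behave alike on another core.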